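The source may hold more compounds than are shown below. What is called first, only, known or untested is meant among the compounds shown, and "the series" means these compounds.

Measured in a toxicity assay on HT-29 cells (Homo sapiens) for cytotoxicity (on this read-out lower numbers stand for higher toxicity in this test and higher numbers for lower toxicity in this test), each entry a limit of the assay:
Compound 1 `CN1C(=S)[C@@H](NC(=O)c2nc(Cc3ccccc3)n(CCCC(F)(F)F)n2)COc2ccccc21`: > 100000 nM
Compound 2 `CN1C(=S)[C@@H](NC(=O)c2nc(Cc3ccccc3)n(C3CCC3)n2)COc2ccccc21`: > 100000 nM
Compound 3 `CN1C(=S)[C@@H](NC(=O)c2nc(Cc3ccccc3)n(C3CCCCC3)n2)COc2ccccc21`: > 100000 nM

Compound 3 stands at > 100000 nM, which is a limit and not a number. Compound 1 and compound 2 are also reported only as limits, so the series has no numerical ranking: the limit of > 100000 nM in this assay, at which 3 of the 3 values shown sit.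

The next step leads to compound 4 `CN1C(=S)[C@@H](NC(=O)c2nc(Cc3ccccc3)n(CC3COC3)n2)COc2ccccc21`, with (oxetan-3-yl)methyl in place of cyclohexyl on an aromatic nitrogen. Unlike the groups measured so far at this nitrogen, the entering group holds a hetero atom, so the change goes beyond what has been tested.

Three measured steps change the group at the same nitrogen: a step that the two limits leave unreadable from compound 1 to compound 2, a step that the two limits leave unreadable from compound 1 to compound 3 and a step that the two limits leave unreadable from compound 2 to compound 3. None of them has a readable size, and none gives a measured direction. In this assay, no step beyond the usual scatter is therefore expected, and the estimated change is a number no higher from compound 3 to compound 4 (the limit leaves the size open). This expectation rests on compound 3 at > 100000 nM, a limit. Compound 4 is most likely to be reported only as a limit too.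

The estimate for compound 4 is 100000 nM, with an expected range of 40000 nM to 200000 nM.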

Compound 4, half-maximal cytotoxic concentration: > 100000 nM
Compound 4 gave a limit, no number; the forecaster's own chance of this, stated with the estimate: 90%; the middle value lies on the limit itself.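

In this assay compound 4 gives > 100000 nM, which is a limit and not a number. The steps joining compound 4 to compound 1, compound 2 and compound 3 therefore cannot be read: the limit of > 100000 nM in this assay, at which 4 of the 4 values shown sit.

The compounds shown leave open whether any group on this aromatic nitrogen changes the half-maximal cytotoxic concentration.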